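Shortening the alkyl chain of compound 1

A few compounds are considered here, and "the series" means these few. Any claim that something is new, unique, unknown or untested is made for them only; others in the source may bear on it.

Values in a functional assay on PC-3 cells (Homo sapiens) for inhibition, read by MTT assay, with stated times of 18 h and 4 h; on this read-out higher numbers stand for weaker inhibition and lower numbers for stronger inhibition
compound 1 `CCCCCCCCCCOP(=O)(O)OCCSC(=S)N1CCCCCC1` gives 32900 nM
compound 2 `CCCCCCCCCCOP(=O)(O)OCCSC(=S)N1CCCCC1` gives 62500 nM

Going by the values given here, compound 1 stands level with the only other number, the step being a 1.9-fold higher number from compound 1 to compound 2 (0.28 log units; within the scatter), with piperidin-1-yl in place of azepan-1-yl on a thiocarbonyl carbon. The unmeasured compound 3 `CCCCCCOP(=O)(O)OCCSC(=S)N1CCCCCC1` differs from compound 1 by hydrogen in place of butyl on a saturated chain carbon, six bonds along the chain from an oxygen on an unsaturated carbon. Among the compounds with values here, the one measured step leaves this chain untouched, so no measured step sizes the change. A moderate, poorly constrained step toward weaker inhibition in this assay is expected, on the structural change alone. The expected shift is a 2.7-fold higher number from compound 1 to compound 3 (0.44 log units; beyond the scatter) and remains an estimate. Compound 3 is estimated at 90000 nM, with an expected range of 35000 nM to 230000 nM in this estimate.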

Compound 3, half-maximal inhibitory concentration: > 100000 nM
Compound 3: no number, only a limit (the forecaster's own chance of this, stated with the estimate: 25%); at least 1.1-fold (0.04 log units) between middle value and limit.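

In this assay compound 3 reads > 100000 nM, which is a limit of the assay and not a number. Hydrogen in place of butyl on a saturated chain carbon, six bonds along the chain from an oxygen on an unsaturated carbon, still gives a readable step of an at least 3.0-fold higher number from compound 1 to compound 3 (0.48 log units; beyond the scatter), so this part of the chain, unchanged between the earlier two compounds, does bear on the read-out, with the shorter chain on the weaker side. The step has only a lower bound and no true size: the limit of > 100000 nM in this assay, at which 1 of the 3 values shown sits.

On these data alone, how far compound 3 lies past its limit stays open, as does whether the exchange of azepan-1-yl for piperidin-1-yl on the thiocarbonyl carbon would read the same on the shorter chain. Also open, as far as these compounds go, is whether a longer chain, or an amine or a carboxylic acid in place of butyl, would strengthen or weaken inhibition.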